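This account rests on a few compounds, and the source may have more. Where it says the series, first, only, none or still open, it means among the compounds named here.

Two compounds share one core and differ only in the group carried by the amine nitrogen in the ring. Compound 1 `CCN1CCCC(NC(=O)c2c(OC)cc(C(F)(F)F)cc2C(F)(F)F)(c2ccccc2)C1` carries an ethyl group there; in an assay on cells for inhibition of sodium- and chloride-dependent glycine transporter 1 (Homo sapiens) (a higher number here means that more compound is needed for the effect, a lower number that less compound is needed), compound 1 gives 230 nM. Compound 2 `COc1cc(C(F)(F)F)cc(C(F)(F)F)c1C(=O)NC1(c2ccccc2)CCCN(C2CCCC2)C1` carries a cyclopentyl group instead; in this assay compound 2 gives 270 nM. On the numbers shown compound 2 stands nearest to compound 1, and the step of a 1.2-fold higher number from compound 1 to compound 2 (0.07 log units; within the scatter) lies within the scatter. Compound 3 `COc1cc(C(F)(F)F)cc(C(F)(F)F)c1C(=O)NC1(c2ccccc2)CCCN(CC2CC2)C1` differs from compound 2 in one place: cyclopropylmethyl in place of cyclopentyl on an amine nitrogen in a ring. Within the data shown here, only the step from compound 1 to compound 2 bears on this change, and that step exchanged one group on the same nitrogen for another without moving the number beyond the scatter. No movement beyond the scatter is therefore expected in this assay, and the expected step is a 1.1-fold lower number from compound 2 to compound 3 (0.03 log units; within the scatter). For compound 3 the estimate in this assay is 250 nM, with a range from 120 nM to 550 nM.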

Compound 3, half-maximal effective concentration: 380 nM
Compound 3: the middle estimate sits 1.5-fold (0.18 log units) below what was measured; low and high end bracket the measured number.
By their numbers in this assay, from the lowest: compounds 1, 2 and 3 (each within the scatter of the next).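

Exchanging cyclopentyl for cyclopropylmethyl on the amine nitrogen in the ring gives a 1.4-fold higher number from compound 2 to compound 3 (0.15 log units; within the scatter) in this assay and, measured against the ethyl group, a 1.7-fold higher number from compound 1 to compound 3 (0.22 log units; within the scatter) as well. This nitrogen has now carried three different carbon-only groups, including one with a five-membered ring and one with a three-membered ring, and every step among them stays within the scatter. Nothing available explains why the numbers stay this close.

On these data alone, all three groups are built of carbon and hydrogen alone, so it remains open whether a group on this nitrogen containing an alcohol, an amide or a carboxylic acid would keep the number in the same range. As far as these compounds go, a much longer chain, a benzyl group or a bare hydrogen at this position also remains open.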